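Trimming the alkyl on a cyanoguanidine series

The source may hold more compounds than are shown below. What is called first, only, known or untested is meant among the compounds shown, and "the series" means these compounds.

Going by the values given here, compound 2 `CC(C)C(C)(C)/N=C(\NC#N)Nc1cc(Cl)cc(C#N)c1` is the only member of this set with a numerical reading in a functional assay with Cavia porcellus as the target (on this read-out higher numbers stand for an effect only at larger amounts of compound and lower numbers for an effect already at smaller amounts), where compound 2 gives 0.19 uM. Compound 1 `CCC(CC)(CC)/N=C(\NC#N)Nc1cc(Cl)cc(C#N)c1` carries a 1,1-diethylpropyl group on the double-bonded nitrogen instead. In this assay compound 1 gives only a limit of > 1 uM, not a number. Among the compounds with values here, the step of an at least 5.2-fold lower number from compound 1 to compound 2 (0.72 log units; beyond the scatter) is the one comparison available, and its size rests on (the limit of > 1 uM in this assay, at which 1 of the 2 values shown sits). Compound 3 `CCC(C)(C)/N=C(\NC#N)Nc1cc(Cl)cc(C#N)c1` takes the change further: hydrogen in place of methyl on a saturated chain carbon bound to two saturated chain carbons, which reads as 1,1,2-trimethylpropyl to 1,1-dimethylpropyl. The measured step points toward a lower number with a smaller alkyl group, but it is anchored on a limit, so only a small continuation, within the scatter, is expected here. Compound 3 is therefore expected to give 0.3 uM, with a range of 0.06 uM to 1.5 uM, an expected step of a 1.6-fold higher number from compound 2 to compound 3 (0.20 log units; within the scatter).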

Compound 3, concentration for half-maximal effect: 0.02 uM
For compound 3 the middle estimate is 15-fold (1.18 log units) above the measured one, and the stated range ends above it.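

Removing a single methyl, 1,1,2-trimethylpropyl to 1,1-dimethylpropyl, gives a 9.5-fold lower number from compound 2 to compound 3 (0.98 log units; beyond the scatter) in this assay, so the run toward lower numbers with a smaller alkyl group does not stop at compound 2 and now rests on two measured values. Over the whole set, the change from the largest to the smallest group shown gives an at least 50-fold lower number from compound 1 to compound 3 (1.69 log units; beyond the scatter). Compound 1 enters that span only as a limit, so its size is a lower bound: the limit of > 1 uM in this assay, at which 1 of the 3 values shown sits.

The compounds shown leave open whether a tert-butyl or isopropyl group on the double-bonded nitrogen would extend this run or end it, and how a ring such as cyclohexyl would compare. On these data alone, the chlorine and nitrile are the same in all three, so what a methoxy group in their place would do also stays open.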